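Chain length in the ether-linked hydroxamates

The source may report more compounds than this note shows. Statements on the series, on what has been measured and on what is new or still open speak of the compounds shown alone.

Among the measured compounds shown here, compound 1 `Cc1noc(C)c1-c1cc(OCCCCCCCC(=O)NO)cc(C(=O)c2ccccc2)c1` gives -0.31 degrees C in an assay for binding affinity to histone acetyltransferase KAT2B (Homo sapiens), tested at 25 uM (a lower number here means that the compound stabilises the target less, a higher number that the compound stabilises the target more against heat), the lower of the two numbers measured so far. Compound 2 `Cc1noc(C)c1-c1cc(NC(=O)CCCCCC(=O)NO)cc(C(=O)c2ccccc2)c1` carries an amide link and a shorter chain in place of the ether chain of compound 1. In this assay compound 2 gives 0.92 degrees C, a number higher than that of compound 1 by more than the scatter; with two compounds that differ in more than one place, nothing further can be drawn from that gap.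

Compound 3 `Cc1noc(C)c1-c1cc(OCCCCCC(=O)NO)cc(C(=O)c2ccccc2)c1` is compound 1 with hydroxycarbamoyl in place of 2-(hydroxycarbamoyl)ethyl on a saturated chain carbon, five bonds along the chain from an oxygen on an aromatic ring, so the chain between the aromatic oxygen and the hydroxamic acid is shorter. For the measured compounds named here, no pair of measured compounds shows the effect of such a shortening alone. In this assay the step from compound 1 to compound 3 is expected to be a number 0.21 degrees C higher from compound 1 to compound 3 (within the scatter), within the scatter. Compound 3 is expected to give -0.1 degrees C, with a range from -1.2 degrees C to 1 degrees C.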

Compound 3, shift of the target's melting temperature: 0.28 degrees C
Compound 3: the middle estimate sits 0.38 degrees C below what was measured; the measured number falls inside the stated range.
By their numbers in this assay, from the lowest: compounds 1, 3 and 2 (each within the scatter of the next, the first and the last beyond it).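

In this assay, the replacement of 2-(hydroxycarbamoyl)ethyl by hydroxycarbamoyl on a saturated chain carbon, five bonds along the chain from an oxygen on an aromatic ring, gives a number 0.59 degrees C higher from compound 1 to compound 3 (within the scatter). Among the compounds shown here, this is the first reading of chain shortening on its own, and at this position the change does not separate the two ether-linked hydroxamates beyond the scatter. No measurement at hand offers an explanation for this result.

Whether the amide link accounts for the gap between compound 1 and compound 2 stays open, since no pair shown isolates that link from chain length. Also open, as far as these compounds go, is how a chain shorter than that of compound 3, or a carboxylic acid in place of the hydroxamic acid, would read in this assay.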